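From compound 1 to compound 3: replacing 3-methoxyphenyl

A few compounds are considered here, and "the series" means these few. Any claim that something is new, unique, unknown or untested is made for them only; others in the source may bear on it.

In a physicochemical assay for solubility, using the shake flask method, in phosphate buffer, with a stated time of 24 h, at pH 7.4 (a higher number here means a more soluble compound, a lower number a less soluble compound), compound 1 `COc1cccc(C(C)Sc2nc3c(cnn3C)c(=O)n2-c2ccccc2)c1` gives < 2000 nM, which is a limit of the assay and not a number. Among the compounds with values here, compound 2 `Cn1ncc2c(=O)n(-c3ccccc3)c(CCc3cccc(F)c3)nc21` gives 126000 nM in this assay, but no measured step connects compounds that differ in one place. Compound 3 `CC(Sc1nc2c(cnn2C)c(=O)n1-c1ccccc1)c1cccnc1` carries pyridin-3-yl in place of 3-methoxyphenyl on a saturated chain carbon bound to a saturated chain carbon and a sulfur. The expected step in this assay is upward and beyond the scatter, and it is estimated as an at least 3.0-fold higher number from compound 1 to compound 3 (0.47 log units; beyond the scatter). For compound 3, the estimated value is 6000 nM, with an expected range of 1500 nM to 25000 nM.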

Compound 3, solubility: 209000 nM
Compound 3: the middle estimate sits 35-fold (1.54 log units) below what was measured, outside the stated range (above it).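

In this assay, within the data shown here, pyridin-3-yl in place of 3-methoxyphenyl on a saturated chain carbon bound to a saturated chain carbon and a sulfur gives an at least 100-fold higher number from compound 1 to compound 3 (2.01 log units; beyond the scatter), the first step that can be read at this position. Compound 1 gives < 2000 nM, which is a limit of the assay and not a number. The step size is therefore a floor, and the true gap stays unfixed: the limit of < 2000 nM in this assay, at which 1 of the 3 values shown sits.

Open, from the compounds shown here alone, is how pyridin-4-yl or an aminophenyl would read at the same place in this assay. Also open, going by these compounds, is whether the step carries over to a core with a chain lacking the sulfur.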